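Swapping the Fluorophenyl Ethynyl End for a Pyridazinyl Ethynyl

The source may report more compounds than this note shows. Statements on the series, on what has been measured and on what is new or still open speak of the compounds shown alone.

Compound 1, `CNC(=O)[C@@]12C[C@@H]1[C@@H](n1cnc3c(NC)nc(C#Cc4ccc(-c5ccccc5)cc4)nc31)[C@H](O)[C@@H]2O`: 18%
Compound 2, `CNC(=O)[C@@]12C[C@@H]1[C@@H](n1cnc3c(NC)nc(C#Cc4ccc(F)cc4)nc31)[C@H](O)[C@@H]2O`: 27%
Compound 3, `CNC(=O)[C@@]12C[C@@H]1[C@@H](n1cnc3c(NC)nc(C#Cc4ccc(CO)cc4)nc31)[C@H](O)[C@@H]2O`: 16%

These three compounds share one core and differ only in the group at the far end of the triple bond. In an assay on CHO cells for displacement of a labelled ligand from adenosine receptor A1 (Homo sapiens), read by scintillation counting, with a stated time of 60 min, tested at 10 uM (on this read-out higher numbers stand for more inhibition at the one concentration tested (going by the name of the read-out) and lower numbers for less inhibition), compound 2 gives the highest of the three numbers, but its gap to compound 1 lies within the scatter, a number 9 percentage points higher from compound 1 to compound 2 (within the scatter), while its gap to compound 3 lies beyond it, a number 11 percentage points lower from compound 2 to compound 3 (beyond the scatter).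

Compound 4, `CNC(=O)[C@@]12C[C@@H]1[C@@H](n1cnc3c(NC)nc(C#Cc4cccnn4)nc31)[C@H](O)[C@@H]2O`, has not yet been measured. It differs from compound 2 in one place: pyridazin-3-yl in place of 4-fluorophenyl on a triple-bonded carbon. Among the compounds with values here, none of the measured steps changes the aromatic ring itself; each only changes what sits on it. The two steps from compound 1, a number 9 percentage points higher from compound 1 to compound 2 (within the scatter) and a number 2 percentage points lower from compound 1 to compound 3 (within the scatter), are both within the scatter. Within the data shown here, the nearest guide is a number 11 percentage points lower from compound 2 to compound 3 (beyond the scatter), the only step beyond the scatter, and it also moves away from the fluoro of compound 2. A similar modest fall is expected here, a number 9 percentage points lower from compound 2 to compound 4 (within the scatter). Compound 4 is therefore estimated at 18% in this assay, with a range from 5% to 32%.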

Compound 4, a percentage reported as inhibition, at one concentration (the size of the read-out at that concentration, not a potency): 11%
The estimate for compound 4 lay 7 percentage points above the measured number; the measured number falls inside the stated range.
By their numbers in this assay, from the lowest: compounds 4, 3, 1 and 2 (each within the scatter of the next, the first and the last beyond it).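

Replacing the carbon-only ring with a ring holding two hetero atoms gives, in this assay, a number 16 percentage points lower from compound 2 to compound 4 (beyond the scatter), so the ring on the triple-bonded carbon can itself shift this read-out, and not only the group that sits on that ring. The same swap reads differently against the other two compounds, with a number 5 percentage points lower from compound 3 to compound 4 (within the scatter) and a number 7 percentage points lower from compound 1 to compound 4 (within the scatter). The pyridazin-3-yl ring is therefore set apart only from the 4-fluorophenyl group of compound 2, not from the groups of compound 1 or compound 3. Nothing available explains why the numbers fall this way.

Still open, as far as these compounds go, is how a pyridin-3-yl ring, with a single ring nitrogen, would read at this position. So is the effect of an aminomethyl group placed on the pyridazine ring.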